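This account rests on a few compounds, and the source may have more. Where it says the series, first, only, none or still open, it means among the compounds named here.

Among the compounds with values here, compound 3 `Nc1nc(N)c(-c2ccc(NCc3ccc([N+](=O)[O-])cc3)cc2)c(COCc2ccccc2)n1` gives the lowest number of the three compounds measured so far in an in vitro assay on CHOK cells for displacement of a labelled ligand from growth hormone secretagogue receptor type 1 (Homo sapiens); on this read-out higher numbers stand for weaker inhibition and lower numbers for stronger inhibition: compound 3 gives 0.2 nM, where compound 1 `CCc1nc(N)nc(N)c1-c1ccc(NCc2ccc([N+](=O)[O-])cc2)cc1` gives 11 nM and compound 2 `CCc1nc(N)nc(N)c1-c1ccc(NCc2ccc(C(C)=O)cc2)cc1` gives 57 nM. The step from the core of compound 1 to the core of compound 3 is the large one in this set, a 55-fold lower number from compound 1 to compound 3 (1.74 log units; beyond the scatter). Compound 4 `CC(=O)c1ccc(CNc2ccc(-c3c(N)nc(N)nc3COCc3ccccc3)cc2)cc1` keeps the core of compound 3 and alters only the outer ring: acetyl in place of nitro on an aromatic carbon. The same exchange has been made once before, on the core of compound 1, and gave a 5.2-fold higher number from compound 1 to compound 2 (0.71 log units; beyond the scatter). A step of similar size and in the same direction is therefore expected in this assay: a 5.0-fold higher number from compound 3 to compound 4 (0.70 log units; beyond the scatter). Compound 4 is expected to give 1 nM, within a range of 0.4 nM to 3 nM.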

Compound 4, half-maximal inhibitory concentration: 1.2 nM
For compound 4 the middle estimate is 1.2-fold (0.08 log units) below the measured one, and the stated range covers the measured number.
By their numbers in this assay, from the lowest: compound 3; then compound 4; then compound 1; then compound 2.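

Acetyl in place of nitro on this aromatic carbon gives a 6.0-fold higher number from compound 3 to compound 4 (0.78 log units; beyond the scatter), so the change carries over from the core of compound 1 to the benzyloxy core with little alteration in size: the same change on two cores in this assay, a 5.2-fold higher number (0.71 log units; beyond the scatter) from compound 1 to compound 2 and a 6.0-fold higher number (0.78 log units; beyond the scatter) from compound 3 to compound 4, 1.2-fold (0.06 log units) apart, within the scatter of two such steps

Read the other way, benzyloxy in place of methyl gives a 48-fold lower number from compound 2 to compound 4 (1.68 log units; beyond the scatter), so this gain holds with acetyl as well as nitro on the outer ring: the same change on two cores in this assay, a 55-fold lower number (1.74 log units; beyond the scatter) from compound 1 to compound 3 and a 48-fold lower number (1.68 log units; beyond the scatter) from compound 2 to compound 4, 1.2-fold (0.06 log units) apart, within the scatter of two such steps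

The compounds shown carry only nitro and acetyl at this position. As far as these compounds go, how an amine, a carboxylic acid or a nitrile there would read stays open, as does whether the two steps would stay independent with such groups.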